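Moving the Halogen on the Phenoxy Ring: Compound 3 to Compound 4

The source may hold more compounds than are shown below. What is called first, only, known or untested is meant among the compounds shown, and "the series" means these compounds.

Compound 1, `Cc1nn(C)c(Oc2ccccc2F)c1/C=N\CCCCCCOc1cc2oc(=O)cc(C)c2cc1Cl`: > 25000 nM, a limit of the assay.
Compound 2, `Cc1nn(C)c(Oc2ccc(F)c(F)c2)c1/C=N\CCCCCCOc1cc2oc(=O)cc(C)c2cc1Cl`: > 25000 nM, also a limit of the assay.
Compound 3, `Cc1nn(C)c(Oc2ccc(Cl)cc2)c1/C=N\CCCCCCOc1cc2oc(=O)cc(C)c2cc1Cl`: 2080 nM.

These values come from a functional assay on SMMC-7721 cells (Homo sapiens) for antiproliferative activity, read by MTT assay, with a stated time of 72 h; a lower number here means a stronger inhibitor, a higher number a weaker inhibitor. Going by the values given here, compound 3 holds the only number; the other two values are limits, as noted in the limit of > 25000 nM in this assay, at which 2 of the 3 values shown sit. Compound 4, `Cc1nn(C)c(Oc2cccc(Br)c2)c1/C=N\CCCCCCOc1cc2oc(=O)cc(C)c2cc1Cl`, differs from compound 3 by 3-bromophenyl in place of 4-chlorophenyl on an oxygen on an aromatic ring. Among the compounds with values here, two measured steps touch the same phenoxy group: an at least 12-fold lower number from compound 1 to compound 3 (1.07 log units; beyond the scatter) and an at least 12-fold lower number from compound 2 to compound 3 (1.07 log units; beyond the scatter), both large, showing that the halogen pattern on this ring can move the result strongly. Neither step tells which way a 3-bromophenyl will go. For compound 4 the expectation is a somewhat higher number, an estimated 2.4-fold higher number from compound 3 to compound 4 (0.38 log units; beyond the scatter), giving an estimate of 5000 nM with a range from 1500 nM to 25000 nM.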

Compound 4, half-maximal inhibitory concentration: 5080 nM
For compound 4 the middle estimate is 1.0-fold (0.01 log units) below the measured one; the range from low to high includes it.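

In this assay, 3-bromophenyl in place of 4-chlorophenyl gives a 2.4-fold higher number from compound 3 to compound 4 (0.39 log units; beyond the scatter), so a readable number survives a change of both the halogen and its place on the ring. The 3-bromophenyl group also outperforms the two other halogen patterns, with an at least 4.9-fold lower number from compound 2 to compound 4 (0.69 log units; beyond the scatter) and an at least 4.9-fold lower number from compound 1 to compound 4 (0.69 log units; beyond the scatter). Those two steps give only a minimum size: the limit of > 25000 nM in this assay, at which 2 of the 4 values shown sit.

Halogen and place changed together here, so 3-chlorophenyl and 4-bromophenyl would be needed to separate them. From the compounds shown here alone, whether this ring needs a halogen at all remains open, and plain phenyl or an aminophenyl group would test that.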